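A few compounds are considered here, and "the series" means these few. Any claim that something is new, unique, unknown or untested is made for them only; others in the source may bear on it.

Measured so far:
compound 1, `c1cncc(N2CC[C@H]3CN[C@H]3C2)c1`, 48 nM
compound 2, `c1cncc(N2CC[C@@H]3CN[C@@H]3C2)c1`, 260 nM
compound 3, `Clc1ccc(N2CC[C@@H]3CN[C@@H]3C2)cn1`, 25 nM

Compound 2 gives the highest number of the three in a functional assay on HEK293 cells for agonist activity at Neuronal acetylcholine receptor; alpha3/beta4 (Homo sapiens), read by FLIPR; a higher number here means that more compound is needed for the effect, a lower number that less compound is needed. Its mirror image, compound 1, sits lower by a 5.4-fold higher number from compound 1 to compound 2 (0.73 log units; beyond the scatter), a step that rests only on (the fact that compounds 1 and 2 differ only in the configuration as drawn). Compound 3 sits lower still, by a 10-fold lower number from compound 2 to compound 3 (1.02 log units; beyond the scatter), after chloro in place of hydrogen on an aromatic carbon.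

Compound 4, `N#Cc1cncc(N2CC[C@@H]3CN[C@@H]3C2)c1`, has not yet been measured in this assay. It differs from compound 2 by cyano in place of hydrogen on an aromatic carbon.

Going by the values given here, the only measured step that bears on a substituent entering the aromatic ring of compound 2 is the one to compound 3, which was large and downward. Cyano is not chloro and enters at a different ring carbon, so that step is a loose guide rather than a template. A downward step of moderate size is expected for compound 4, estimated as a 2.6-fold lower number from compound 2 to compound 4 (0.41 log units; beyond the scatter).

In this assay compound 4 is expected to give about 100 nM, likely between 30 nM and 300 nM.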

Compound 4, half-maximal effective concentration: 490 nM
For compound 4 the middle estimate is 4.9-fold (0.69 log units) below the measured one, and the stated range ends below it.
By their numbers in this assay, from the lowest: compounds 3 and 1 (each within the scatter of the next); then compounds 2 and 4 (each within the scatter of the next).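

In this assay, cyano on an aromatic carbon two atoms from the ring nitrogen gives a 1.9-fold higher number from compound 2 to compound 4 (0.28 log units; within the scatter), so no change can be claimed for this group at this position. The lowering seen with chloro, a 10-fold lower number from compound 2 to compound 3 (1.02 log units; beyond the scatter), therefore does not extend to every group entering the aromatic ring of compound 2. These two steps differ in both the group and its place on the ring, so the data cannot separate the two, and nothing at hand bears on a cause for the cyano step.

Open, as far as these compounds go, is whether chloro on this same ring carbon would follow the cyano step or the chloro step, and how a methoxy group or an amine would read there. Also open, from the compounds shown here alone, is whether cyano would behave the same way on the mirror-image core of compound 1.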